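The compounds below may be only part of what the source reports. "The series", "measured", "known", "first", "only" and "open" are said of these compounds alone.

Of the compounds shown here, two have been measured so far in a physicochemical assay for lipophilicity, at pH 7.4; a lower number here means a more polar compound, a higher number a more lipophilic compound. Compound 1 `COc1cc(OC)c(NC(=O)Cc2cn(CC(=O)O)c3ccccc23)cc1Cl` gives 2.13, and compound 2 `O=C(O)Cc1nn(Cc2cn3cc(OCC4CC4)c(Cl)cc3n2)c2ccccc2c1=O` gives 2.13. Compound 1 therefore stands level with compound 2, and this is all that the two numbers show. Among the compounds with values here, no two measured compounds differ in just one place, so no measured step is available as a guide.

The next compound, compound 3 `COc1cc(OC)c(NC(=O)Cc2cn(C)c3ccccc23)cc1Cl`, keeps the core of compound 1 and changes in a single place: hydrogen in place of carboxy on a saturated chain carbon bound to an aromatic nitrogen. Hydrogen takes the place of carboxy on a saturated chain carbon bound to an aromatic nitrogen, which turns carboxymethyl into methyl.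

Within the data shown here, with no measured step to set the size, the expectation rests on this structural change alone. A large step towards higher numbers in this assay is expected, well beyond the scatter, starting from compound 1 at 2.13. The estimated step is a number 1.47 log units higher from compound 1 to compound 3 (beyond the scatter). For compound 3 the expected value is 3.6, with an estimated range from 3.1 to 4.1.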

Compound 3, distribution coefficient: 5.91
The estimate for compound 3 lay 2.31 log units below the measured number; measured number outside the range, above it.
By their numbers in this assay, from the lowest: compounds 1 and 2 (each within the scatter of the next); then compound 3.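

In this assay, putting hydrogen in place of carboxy on a saturated chain carbon bound to an aromatic nitrogen, which turns carboxymethyl into methyl, gives a number 3.78 log units higher from compound 1 to compound 3 (beyond the scatter). Within the data shown here, with the rest of the molecule unchanged, this one place is enough to move the reading far beyond the scatter, something that could not be seen while no two measured compounds differed in just one place. Nothing measured here gives an explanation for the size of this step.

This single step has two end points only, so it leaves open how much of the change comes with losing the carboxy group itself and how the reading would respond to other groups at this place, such as an amine, a primary amide or a longer chain ending in a carboxylic acid. It also leaves open whether the same exchange would give a step of similar size on a different core, since it has been read on the core of compound 1 alone.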